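Substitution on the ring amine nitrogen of compound 1

A few compounds are considered here, and "the series" means these few. Any claim that something is new, unique, unknown or untested is made for them only; others in the source may bear on it.

In a functional assay on A549 cells (Homo sapiens) for cytotoxicity, read by MTT assay, with a stated time of 72 h (a lower number here means a stronger inhibitor, a higher number a weaker inhibitor), compound 1 (`CNC(=O)c1cc(Oc2ccc(C3=NNC(c4ccc(C#N)cc4)C3)cc2)ccn1`) gives 17400 nM and compound 2 (`CNC(=O)c1cc(Oc2ccc(C3=NNC(c4ccc(Cl)c(Cl)c4)C3)cc2)ccn1`) gives 10700 nM, two values within the scatter of each other. Compound 3 (`CNC(=O)c1cc(Oc2ccc(C3=NN(C(N)=S)C(c4ccc(C#N)cc4)C3)cc2)ccn1`) differs from compound 1 by a group of 3 heavy atoms (1 carbon, 1 nitrogen, 1 sulfur; no ring) in place of a hydrogen atom, on an amine nitrogen in a ring. For the measured compounds named here, the only measured step, a 1.6-fold lower number from compound 1 to compound 2 (0.21 log units; within the scatter), concerns the 4-cyanophenyl group rather than this nitrogen, so it offers little guidance, and no change at this nitrogen has been measured. The expected step, held loosely, is a 2.2-fold lower number from compound 1 to compound 3 (0.34 log units; beyond the scatter). For compound 3 the estimated value is 8000 nM, with an expected range of 2500 nM to 25000 nM.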

Compound 3, half-maximal inhibitory concentration: > 50000 nM
Compound 3: a limit, no number (the forecaster's own chance of this, stated with the estimate: 10%); at least 6.2-fold (0.79 log units) between middle value and limit.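

For the compounds shown here, this is the first reading at the amine nitrogen in a ring, and it shows that the position is not indifferent to substitution: the group of 3 heavy atoms (1 carbon, 1 nitrogen, 1 sulfur) in place of hydrogen gives an at least 2.8-fold higher number from compound 1 to compound 3 (0.45 log units; beyond the scatter). As far as these compounds go, the true size of this step remains unknown. For compound 3, the result in this assay is a limit and not a number: the limit of > 50000 nM in this assay, at which 1 of the 3 values shown sits.

Open, from the compounds shown here alone, is whether an acetyl group, a methyl group or a carboxamide on this nitrogen would give the same result. Also open, going by these compounds, is whether the same change would act alike alongside the 3,4-dichlorophenyl group of compound 2.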